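A Triazole Replaces the Nitrile-Bearing Side Chain

This account rests on a few compounds, and the source may have more. Where it says the series, first, only, none or still open, it means among the compounds named here.

Three compounds share one core. In an assay on isolated protein for binding affinity to leukotriene B4 receptor 1 (Homo sapiens), tested at 1 uM (a lower number here means less inhibition, a higher number more inhibition at the concentration tested (going by the name of the read-out)), compound 1 `C=CCc1cc(C(C)=O)c(O)cc1OCCCCCCC#N` gives 63%, compound 2 `CCc1cc(C(C)=O)c(O)cc1OCCCCCCCC(C)(C)C#N` gives 29%, and compound 3 `C=CCc1cc(C(C)=O)c(O)cc1OCCCCCC` gives 9%. Compound 2 therefore stands second of the three, separated from both others by more than the scatter. Compound 4 `CCc1cc(C(C)=O)c(O)cc1OCCCCCn1cncn1` differs from compound 2 by 1H-1,2,4-triazol-1-yl in place of 3-cyano-3-methylbutyl on a saturated chain carbon, five bonds along the chain from an oxygen on an aromatic ring. For the measured compounds named here, the only measured step that bears on this, a number 54 percentage points lower from compound 1 to compound 3 (beyond the scatter), shows that removing the cyano group costs a great deal. Going by the values given here, compound 4 also gives up the cyano group, yet gains the 1H-1,2,4-triazol-1-yl ring, for which no measured step exists. The step of a number 1 percentage points higher from compound 2 to compound 4 (within the scatter) is therefore expected to be small, in either direction. Compound 4 is estimated at 30%, with a range from 5% to 60%.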

Compound 4, a percentage reported as inhibition, at one concentration (the size of the read-out at that concentration, not a potency): 30%
For compound 4 middle estimate and measured number coincide at the digits printed, and the stated range covers the measured number.
By their numbers in this assay, from the lowest: compound 3; then compounds 2 and 4 (each within the scatter of the next); then compound 1.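

In this assay, putting 1H-1,2,4-triazol-1-yl in place of 3-cyano-3-methylbutyl gives a number 1 percentage points higher from compound 2 to compound 4 (within the scatter), so the two numbers cannot be told apart. At this place on the chain, the nitrile and the gem-dimethyl carbon of compound 2 can therefore both go without a change beyond the scatter. Nothing measured here accounts for this result.

On these data alone, whether an imidazole or an amine at the same place would read alike remains open. So does whether the triazole would match on a longer chain or on the core of compound 1.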